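The compounds below may be only part of what the source reports. "The series", "measured", "known", "first", "only" and "open" are said of these compounds alone.

Compound 1, whose structure is `Nc1cc(N)c2nc(-c3ccccc3)c(NCc3ccc(Cl)c(Cl)c3)nc2c1`, is the starting point. In a functional assay on NCI-H522 cells (Homo sapiens) for inhibition, read by sulforhodamine B assay, with a stated time of 48 h (on this read-out higher numbers stand for weaker inhibition of growth and lower numbers for stronger inhibition of growth), compound 1 gives 2040 nM, the lowest of the two numbers in hand. Compound 3, with the structure `Nc1cc(N)c2nc(-c3ccccc3)c(Oc3ccc(F)cc3)nc2c1`, gives 64600 nM in this assay, a markedly higher number that lies well beyond the scatter of repeats. Compound 2, with the structure `Nc1cc(N)c2nc(-c3ccccc3)c(Sc3ccc(F)cc3)nc2c1`, is recorded in this assay only as a limit, < 100000 nM, rather than as a number. Among the compounds with values here, the one step between measured compounds, a step that the limit leaves unreadable from compound 2 to compound 3, is therefore of unreadable size, and it concerns a different part of the shared core than the change followed here.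

Compound 4, with the structure `COc1ccc(CNc2nc3cc(N)cc(N)c3nc2-c2ccccc2)cc1OC`, has not yet been measured in this assay. It differs from compound 1 in one place: 3,4-dimethoxyphenyl in place of 3,4-dichlorophenyl on a saturated chain carbon bound to a nitrogen on an aromatic ring. Within the data shown here, no measured step touches this position, so the data give no guide to the direction or size of the effect, and the expectation is that the number for compound 4 stays close to that of compound 1, with no step beyond the usual scatter. On that basis compound 4 is estimated at 3000 nM in this assay, within a range from 800 nM to 12000 nM. This expected step, a 1.5-fold higher number from compound 1 to compound 4 (0.17 log units; within the scatter), is an estimate rather than a measurement.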

Compound 4, concentration for 50% growth inhibition: 2690 nM
The estimate for compound 4 lay 1.1-fold (0.05 log units) above the measured number; the range from low to high includes it.
By their numbers in this assay, from the lowest: compounds 1 and 4 (each within the scatter of the next); then compound 3.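

Replacing the 3,4-dichlorophenyl of compound 1 with the 3,4-dimethoxyphenyl of compound 4, on a saturated chain carbon bound to a nitrogen on an aromatic ring, gives in this assay a 1.3-fold higher number from compound 1 to compound 4 (0.12 log units; within the scatter) and so leaves the two compounds indistinguishable in this test. Within the data shown here, this is the first readable step at this position, and it shows that a group with two chlorine atoms and no hydrogen-bond acceptors can give way to one with two oxygen atoms, two hydrogen-bond acceptors and more heavy atoms without a difference that repeat measurements could separate. Nothing in the data available explains why these two groups give numbers so close together.

Going by these compounds, a single swap cannot show whether this position accepts almost any group, so it remains open whether a plain phenyl ring, a phenyl ring carrying a carboxylic acid or an amine, or a longer chain between the nitrogen and the ring would keep the number in this range. Compounds 1 and 3 differ in more than one place, so the separate contributions of the nitrogen and oxygen links, and of the groups they carry, also remain unresolved.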